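Amino to trifluoromethyl exchange: working notes toward compound 3

The source may hold more compounds than are shown below. What is called first, only, known or untested is meant among the compounds shown, and "the series" means these compounds.

Measured so far:
compound 1 `CC1(C)N=C(N)N=C(N)N1c1ccccc1N` gives 4.11
compound 2 `CC1(C)N=C(N)N=C(N)N1c1ccccc1F` gives 4.86

In an assay for inhibition of Dihydrofolate reductase (Bos taurus), at pH 6.25 (on this read-out lower numbers stand for lower potency and higher numbers for higher potency (the scale is a negative logarithm)), compound 1 gives 4.11, the lowest of the two numbers in hand; its nearest neighbour is compound 2, for which this assay gives 4.86. Among the compounds with values here, the single measured step, a number 0.75 log units higher from compound 1 to compound 2 (beyond the scatter), shows that removing the amino group from the aromatic carbon in favour of a small halogen raises the read-out clearly beyond the scatter.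

Compound 3 `CC1(C)N=C(N)N=C(N)N1c1ccccc1C(F)(F)F` has not yet been tested in this assay. Relative to compound 1 its change is trifluoromethyl in place of amino on an aromatic carbon. Within the data shown here, the one step that bears on it is the fluoro replacement, a number 0.75 log units higher from compound 1 to compound 2 (beyond the scatter), since both steps remove the same amino group from the same aromatic carbon; no measured pair shows a trifluoromethyl group at this place, so its own effect is untested. A gain of the same order as in compound 2, or somewhat larger, is expected, with a wide range to cover the lack of a direct analogue.

For compound 3 the estimated step is a number 0.89 log units higher from compound 1 to compound 3 (beyond the scatter). In this assay compound 3 is expected at 5, within 4.4 to 5.6.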

Compound 3, logarithm of the reciprocal of the active concentration, log(1/C): 3.15
The estimate for compound 3 lay 1.85 log units above the measured number, outside the stated range (below it).
By their numbers in this assay, from the lowest: compound 3; then compound 1; then compound 2.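

Working notes after compound 3

In this assay, taking the amino group off this aromatic carbon does not in itself raise the number: the outcome turns on the group that enters, as trifluoromethyl gives a number 0.96 log units lower from compound 1 to compound 3 (beyond the scatter) against the gain seen with fluoro, a number 0.75 log units higher from compound 1 to compound 2 (beyond the scatter) in the opposite direction. The widest gap in the series lies between the two fluorine-bearing groups, with a number 1.71 log units lower from compound 2 to compound 3 (beyond the scatter) on the same carbon, so the presence of fluorine alone does not set the read-out at this place, ortho to a large group, and amino falls between fluoro and trifluoromethyl in the order of the three compounds. No measurement at hand bears on why the number falls with trifluoromethyl.

The three compounds leave open whether the read-out follows the heavy-atom count of the entering group or the identity of that group, and chloro, methyl or methoxy on the same carbon would test this. Also open, going by these compounds, is whether the same order of amino, fluoro and trifluoromethyl holds on other carbons of the aromatic ring, or with a plain hydrogen as the reference.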